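This account rests on a few compounds, and the source may have more. Where it says the series, first, only, none or still open, it means among the compounds named here.

Measured so far:
- compound 1, `CC(C)(C)OC(=O)NCCCCNC(=O)CN1CN(c2ccccc2)C2(CCN(C(=O)c3ccc(C(C)(C)C)cc3)CC2)C1=O`: "not determined" (no result reported) in an assay on HEK293 cells for displacement of a labelled ligand from NPC1-like intracellular cholesterol transporter 1 (Homo sapiens); a higher number here means a weaker inhibitor, a lower number a stronger inhibitor
- compound 2, `CC(C)(C)c1ccc(C(=O)N2CCC3(CC2)C(=O)N(CC(=O)NCCN)CN3c2ccccc2)cc1`: 7000 nM

In this assay, among the compounds with values here, compound 2 gives 7000 nM, and this is the only number recorded here. Within the data shown here, compound 1 has no reported result, so compound 2 stands alone and no step between two measured compounds can be read from these data. Compound 3, `CC(C)(C)c1ccc(C(=O)N2CCC3(CC2)C(=O)N(CC(=O)NCCCCCNS(C)(=O)=O)CN3c2ccccc2)cc1`, differs from compound 2 by 3-(methanesulfonamido)propyl in place of amino on a saturated chain carbon, two bonds along the chain from an amide-type nitrogen. Among the measured compounds shown here, with no measured step to lean on, the change at the far end of the chain is expected to shift the half-maximal inhibitory concentration only modestly, perhaps toward somewhat stronger binding, though a result that stays within the usual scatter is just as plausible. The step this implies is expected to be a 1.8-fold lower number from compound 2 to compound 3 (0.24 log units; within the scatter). Compound 3 is therefore estimated at 4000 nM, with a likely range from 1000 nM to 20000 nM.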

Compound 3, half-maximal inhibitory concentration: 5500 nM
Compound 3: middle estimate off by 1.4-fold (0.14 log units), on the low side, within the range that was stated.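

In this assay, putting 3-(methanesulfonamido)propyl in place of amino on a saturated chain carbon, two bonds along the chain from an amide-type nitrogen, gives a 1.3-fold lower number from compound 2 to compound 3 (0.10 log units; within the scatter), so the two compounds cannot be told apart. This place therefore accepts a group of 8 heavy atoms, including a sulfur and two oxygens, in place of a single nitrogen without a measurable loss or gain in this read-out. No evidence is available to explain this result.

Steps involving compound 1 cannot be read, as it has no reported result. From the compounds shown here alone, it remains open whether a free amine on a pentyl chain would read like compound 2 or compound 3, which would separate the chain length from the methanesulfonamide, and whether a carboxylic acid at this place would give a different number.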